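A few compounds are considered here, and "the series" means these few. Any claim that something is new, unique, unknown or untested is made for them only; others in the source may bear on it.

- Compound 1 `Nc1noc2ccc(-n3nc(C(F)(F)F)c4c3C(=O)N(c3ccc(-c5ccccc5CN5CCCC5)cc3F)CC4)cc12` gives 4.9 h
- Compound 2 `CN(C)Cc1ccccc1-c1ccc(N2CCc3c(C(F)(F)F)nn(-c4ccc5onc(N)c5c4)c3C2=O)c(F)c1` gives 6.4 h

In an in vivo ADME assay on the whole organism for metabolic stability, with Canis familiaris (Canis lupus familiaris) as the target (on this read-out higher numbers stand for a longer-lived compound and lower numbers for a shorter-lived compound), compound 2 stands at 6.4 h, level with compound 1 within the scatter. Compound 3 `Nc1noc2ccc(-n3nc(C(F)(F)F)c4c3C(=O)N(c3ccc(-c5ccccc5CN5CC[C@@H](O)C5)cc3F)CC4)cc12` differs from compound 2 by 3-hydroxypyrrolidin-1-yl in place of dimethylamino on a saturated chain carbon bound to an aromatic carbon. For the measured compounds named here, the one measured step at this place is a 1.3-fold higher number from compound 1 to compound 2 (0.12 log units; within the scatter), which exchanges pyrrolidin-1-yl and dimethylamino. Going by the values given here, no measured compound carries 3-hydroxypyrrolidin-1-yl, so that step is only a rough guide. The expected change is a 1.3-fold lower number from compound 2 to compound 3 (0.12 log units; within the scatter), with no shift expected beyond the scatter. For compound 3 the estimated half-life in this assay is 4.8 h, with an expected range from 2.4 h to 9 h.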

Compound 3, half-life: 5.9 h
Compound 3: the middle estimate sits 1.2-fold (0.09 log units) below what was measured, and the stated range covers the measured number.
By their numbers in this assay, from the lowest: compounds 1, 3 and 2 (each within the scatter of the next).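

Exchanging dimethylamino for 3-hydroxypyrrolidin-1-yl adds a ring, a hydrogen-bond donor and a defined stereocentre, yet in this assay it gives a 1.1-fold lower number from compound 2 to compound 3 (0.04 log units; within the scatter) on the same saturated chain carbon bound to an aromatic carbon. Adding only the hydroxy to the pyrrolidine ring gives a 1.2-fold higher number from compound 1 to compound 3 (0.08 log units; within the scatter), so neither change moves the half-life beyond the scatter. Nothing available explains why these three amines sit level. Still open, as far as these compounds go, is whether a carboxylic acid or a piperazine at this place would also leave the half-life level. From the compounds shown here alone, the opposite stereocentre of 3-hydroxypyrrolidin-1-yl is equally open.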